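The compounds below may be only part of what the source reports. "The series", "measured", "known", "first", "only" and "open" are said of these compounds alone.

Measured compounds in a functional assay (strain AB) with Danio rerio as the target, read by microscopy, with a stated time of 1 h; a higher number here means that more compound is needed for the effect, a lower number that less compound is needed:
- compound 1 `CC[N+]1(C)CCc2c(sc(NC(=O)Nc3ccc(Cl)cc3)c2C(N)=O)C1` gives 1960 nM
- compound 2 `CN1CCc2c(sc(NC(=O)Nc3ccc(Cl)cc3)c2C(N)=O)C1` gives 4700 nM
- compound 3 `CC(C)(C)OC(=O)CCCCCN1CCc2c(sc(NC(=O)Nc3ccc(Cl)cc3)c2C(N)=O)C1` gives 620 nM

Compound 1 stands second highest of the three numbers in this assay. Its nearest neighbour by value is compound 2, whose number is higher and beyond the scatter; compound 3 has the lowest number, below compound 1 beyond the scatter.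

Compound 4 `C[N+]1(CC2CCCC2)CCc2c(sc(NC(=O)Nc3ccc(Cl)cc3)c2C(N)=O)C1` is not yet measured. Relative to compound 1 the change is cyclopentyl in place of methyl on a saturated chain carbon bound to an amine nitrogen in a ring; taken one bond further out, it reads ethyl to cyclopentylmethyl on the ring nitrogen.

Within the data shown here, the one measured step that bears on it is a 7.6-fold lower number from compound 2 to compound 3 (0.88 log units; beyond the scatter), where a larger group entered at the same place, on a saturated chain carbon bound to an amine nitrogen in a ring, and the number went down modestly. Compound 1 against compound 2 also shows a lower number where the ring nitrogen carries more. On that basis a modest downward step is expected for compound 4, a 2.5-fold lower number from compound 1 to compound 4 (0.39 log units; beyond the scatter), though the cyclopentyl group is smaller than the chain that entered in compound 3, so a smaller shift than that step is expected.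

Compound 4 is estimated at 800 nM, with a range of 350 nM to 1800 nM.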

Compound 4, half-maximal effective concentration: 200 nM
Compound 4: middle estimate off by 4.0-fold (0.60 log units), on the high side; measured number outside the range, below it.
By their numbers in this assay, from the lowest: compound 4; then compound 3; then compound 1; then compound 2.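

In this assay, a 9.8-fold lower number from compound 1 to compound 4 (0.99 log units; beyond the scatter) shows that the place on a saturated chain carbon bound to an amine nitrogen in a ring also accepts a five-membered ring of carbon only, with the number going down. The earlier step, a 7.6-fold lower number from compound 2 to compound 3 (0.88 log units; beyond the scatter), involved a chain ending in an ester, whereas cyclopentyl has 0 hydrogen-bond acceptors, so a lower number at this place does not depend on such an ester among the compounds shown. No measurement shown gives a reason for the step.

The compounds shown do not separate the effect of the ring itself from that of the added carbons, which a straight pentyl chain at the same place would address. From the compounds shown here alone, it also remains open how cyclohexyl, phenyl, an amine or a carboxylic acid would fare there.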